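Swapping a Nitrophenyl for a Chlorofluorophenyl Group

The compounds below may be only part of what the source reports. "The series", "measured", "known", "first", "only" and "open" are said of these compounds alone.

Of the compounds shown here, two of the shared core have been measured in a functional assay (aorta) with Rattus norvegicus as the target; on this read-out lower numbers stand for stronger inhibition and higher numbers for weaker inhibition. Compound 1 `CC1(C)Oc2ccc(C#N)cc2[C@@H](NC(=O)Nc2ccccn2)[C@@H]1O` carries a pyridinyl urea on the core and gives 440 nM. Compound 2 `CC1(C)Oc2ccc(C#N)cc2[C@@H](/N=C(\NC#N)Nc2cccc([N+](=O)[O-])c2)[C@@H]1O` replaces that urea with a cyanoguanidine bearing a 3-nitrophenyl group, and in this assay compound 2 gives 670 nM. Compound 2 stands alongside compound 1: the two numbers lie within the scatter of each other, so nothing can be said about their order or about any change between them.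

Compound 3 `CC1(C)Oc2ccc(C#N)cc2[C@@H](/N=C(\NC#N)Nc2ccc(Cl)c(F)c2)[C@@H]1O` keeps the cyanoguanidine of compound 2 and differs in one place: 4-chloro-3-fluorophenyl in place of 3-nitrophenyl on an amine nitrogen. For the measured compounds named here, no step between measured compounds of this kind is available, so the expectation for this assay rests on compound 2 alone.

Compound 3 is expected to stay close to compound 2, with a step of a 1.3-fold lower number from compound 2 to compound 3 (0.13 log units; within the scatter) that does not reach beyond the scatter in either direction. The estimate for compound 3 in this assay is 500 nM, with a range from 150 nM to 1600 nM.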

Compound 3, half-maximal inhibitory concentration: 1660 nM
Beside the measured number, compound 3's estimate is 3.3-fold (0.52 log units) below it; the whole stated range lies below it.
By their numbers in this assay, from the lowest: compounds 1 and 2 (each within the scatter of the next); then compound 3.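

In this assay, putting 4-chloro-3-fluorophenyl in place of 3-nitrophenyl on an amine nitrogen gives a 2.5-fold higher number from compound 2 to compound 3 (0.39 log units; beyond the scatter), a modest step towards weaker inhibition. This is the only pair shown that differs in one place, and it shows that the aryl group on this nitrogen of the cyanoguanidine does bear on the read-out, which compound 1 and compound 2 could not show: they differ in more than that group and lie within the scatter of each other. Nothing available accounts for the size or direction of this step, so the result stands here as an observation only.

The change removes the nitro group and brings in both a chlorine and a fluorine at once, so the compounds shown leave open which of these alterations carries the step. On these data alone, how the number would respond to an unsubstituted phenyl or a methoxyphenyl on the same nitrogen also stays open, and so does whether the same swap would give a similar step on a urea such as that of compound 1.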